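Moving the Bromine on the Aryl Ring: Compound 1 to Compound 4

A few compounds are considered here, and "the series" means these few. Any claim that something is new, unique, unknown or untested is made for them only; others in the source may bear on it.

Compound 1 `COc1cc(/C=N/Nc2nc(-c3ccc(Br)cc3)cs2)cc(Br)c1OC` gives 36200 nM in a functional assay on Caco-2 cells (Homo sapiens) for inhibition, read by MTT assay, with a stated time of 48 h; a lower number here means a stronger inhibitor, a higher number a weaker inhibitor. Compound 3 `Fc1ccc(/C=N/Nc2nc(-c3ccccc3)cs2)cc1F` gives 20900 nM in this assay. Compound 2 `COc1cc(/C=N/Nc2nc(-c3cc(C(F)(F)F)cc(C(F)(F)F)c3)cs2)c(Br)c(Br)c1OC` reaches only a limit of this assay, > 100000 nM, and no number.

So only two numbers are known, and compound 1 and compound 3 sit close together, with their gap inside the usual scatter of repeated measurements; neither can be called the stronger inhibitor. Compound 4 `COc1cc(/C=N/Nc2nc(-c3cccc(Br)c3)cs2)cc(Br)c1OC` has the same atoms as compound 1 joined differently: 3-bromophenyl in place of 4-bromophenyl on an aromatic carbon. Among the measured compounds shown here, no measured pair shows what such a move does, so the expected step from compound 1 to compound 4, a 1.0-fold higher number from compound 1 to compound 4 (0.02 log units; within the scatter), is none beyond the scatter. Compound 4 is therefore estimated at 38000 nM, within a range from 12000 nM to 120000 nM.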

Compound 4, half-maximal inhibitory concentration: 43400 nM
For compound 4 the middle estimate is 1.1-fold (0.06 log units) below the measured one; the measured number falls inside the stated range.
By their numbers in this assay, from the lowest: compounds 3, 1 and 4 (each within the scatter of the next, the first and the last beyond it). At a limit, above all of these: compound 2.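

Moving the bromine, with 3-bromophenyl in place of 4-bromophenyl on the aromatic carbon next to the ring nitrogen, gives the first direct reading at this position in this assay (a 1.2-fold higher number from compound 1 to compound 4 (0.08 log units; within the scatter)). At this position, the two bromine placements therefore cannot be told apart in this measurement. Nothing measured here speaks to why the two compounds read alike. Open, going by these compounds, is whether a different group on this phenyl ring, such as an amine or a carboxylic acid, would give a number clearly apart from that of compound 1.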